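From Naphthalene to Dichloropyridine at the Amide-Bound Carbon

A few compounds are considered here, and "the series" means these few. Any claim that something is new, unique, unknown or untested is made for them only; others in the source may bear on it.

Measured so far in an assay on isolated protein for inhibition of RAC-alpha serine/threonine-protein kinase (Homo sapiens); on this read-out lower numbers stand for stronger inhibition and higher numbers for weaker inhibition:
- compound 1 `O=C(NC(c1ccc2ccccc2c1)C1CCNCC1)c1ccc2cnccc2c1` gives 400 nM
- compound 2 `O=C(NC(c1nccs1)C1CCNCC1)c1ccc2cnccc2c1` gives 1570 nM
- compound 3 `O=C(NC(c1cccc(Cl)c1)C1CCNCC1)c1ccc2cnccc2c1` gives 70 nM

Within this small set compound 1 holds the second highest number. Its nearest neighbour is compound 2, reached by a 3.9-fold higher number from compound 1 to compound 2 (0.59 log units; beyond the scatter), and its furthest is compound 3, reached by a 5.7-fold lower number from compound 1 to compound 3 (0.76 log units; beyond the scatter). Between those two ends lies a 22-fold lower number from compound 2 to compound 3 (1.35 log units; beyond the scatter), so the group on the saturated chain carbon bound to an amide-type nitrogen and a saturated ring carbon clearly matters in this assay.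

Compound 4 `O=C(NC(c1cnc(Cl)c(Cl)c1)C1CCNCC1)c1ccc2cnccc2c1` has not yet been measured. It differs from compound 1 in one place: 5,6-dichloropyridin-3-yl in place of naphthalen-2-yl on a saturated chain carbon bound to an amide-type nitrogen and a saturated ring carbon

For the measured compounds named here, two measured steps bear on this change. Compound 3 shows that a six-membered ring carrying a chlorine gives a clearly lower number than the naphthalen-2-yl of compound 1, while compound 2 shows that a small ring with a hetero atom gives a clearly higher one. The entering group combines both features, a six-membered ring with chlorines and one ring nitrogen, so a modest step toward a lower number is expected, a 2.7-fold lower number from compound 1 to compound 4 (0.43 log units; beyond the scatter), though not beyond what compound 3 achieved. Compound 4 is therefore estimated at 150 nM, within a range from 40 nM to 600 nM.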

Compound 4, half-maximal inhibitory concentration: 140 nM
The estimate for compound 4 lay 1.1-fold (0.03 log units) above the measured number; the range from low to high includes it.
By their numbers in this assay, from the lowest: compounds 3 and 4 (each within the scatter of the next); then compound 1; then compound 2.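

Replacing naphthalen-2-yl with 5,6-dichloropyridin-3-yl gives a 2.9-fold lower number from compound 1 to compound 4 (0.46 log units; beyond the scatter) in this assay, so a single six-membered aromatic ring with a ring nitrogen can outperform the larger two-ring group at this position. Set against the 3-chlorophenyl group, the same ring gives a 2.0-fold higher number from compound 3 to compound 4 (0.30 log units; within the scatter), so compound 3 and compound 4 cannot be told apart here, although the ring nitrogen and the second chlorine enter together and their separate contributions stay hidden. The large gap to the thiazole, an 11-fold lower number from compound 2 to compound 4 (1.05 log units; beyond the scatter), also shows that a hetero atom in the ring does not by itself go with a high number, since compound 4 has one and still sits far from compound 2.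

No available evidence explains why these groups differ in this way. Still open, going by these compounds, is how a plain pyridin-3-yl ring without chlorine would compare, and whether a methoxy group, an amine or a carboxylic acid in place of the chlorines would keep the number as low as in compound 3 and compound 4.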